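Chloro for Methyl on a Triazole-Linked Sulfonamide

A few compounds are considered here, and "the series" means these few. Any claim that something is new, unique, unknown or untested is made for them only; others in the source may bear on it.

Measured so far:
Compound 1, `O=c1[nH]cc(S(=O)(=O)Nc2cccc(-c3cn(-c4cccc(Cl)c4)nn3)c2)c(=O)[nH]1`: 2430 nM
Compound 2, `Cc1ccc(-n2cc(-c3ccc(NS(=O)(=O)c4c[nH]c(=O)[nH]c4=O)cc3)nn2)cc1`: 5560 nM

Both were tested in a functional assay on A549 cells (Homo sapiens) for antiproliferative activity, read by MTT assay, with a stated time of 24 h; a higher number here means a weaker inhibitor, a lower number a stronger inhibitor. Of the two numbers, compound 2 gives the higher one at 5560 nM, which makes it the weaker inhibitor of the pair; compound 1 gives 2430 nM, and the gap between them lies beyond the usual scatter, so compound 2 is the weaker of the two.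

Compound 3, `O=c1[nH]cc(S(=O)(=O)Nc2ccc(-c3cn(-c4ccc(Cl)cc4)nn3)cc2)c(=O)[nH]1`, has not yet been measured. It differs from compound 2 in one place: chloro in place of methyl on an aromatic carbon. One heavy atom leaves and one heavy atom enters, and neither the ring count nor the donors and acceptors change. No step of this kind exists between the measured compounds, so nothing shown here fixes its direction. Compound 1 also carries a chloro, but on a different place and with a different ring pattern, so its lower number cannot be read as the effect of that group alone.

The expected step in this assay, a 1.4-fold lower number from compound 2 to compound 3 (0.14 log units; within the scatter), is small and likely within the scatter, with a slight tilt toward a lower number. Compound 3 is therefore expected to give about 4000 nM, with a range of 1500 nM to 10000 nM.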

Compound 3, half-maximal inhibitory concentration: 1210 nM
For compound 3 the middle estimate is 3.3-fold (0.52 log units) above the measured one; measured number below the stated range.
By their numbers in this assay, from the lowest: compounds 3 and 1 (each within the scatter of the next); then compound 2.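

In this assay, putting chloro in place of methyl on the aromatic carbon para to a large group gives a 4.6-fold lower number from compound 2 to compound 3 (0.66 log units; beyond the scatter) on an otherwise unchanged structure. This is the only step shown between compounds that differ in one place, so it shows that the exchange of a single heavy atom at this position is enough to move the number beyond the usual scatter, and it sets the direction for 4-methylphenyl to 4-chlorophenyl. The data shown offer no explanation for this step, as no supporting measurement of any kind accompanies the two compounds.

The compounds shown place only methyl and chloro at this position, so it remains open how a fluoro, a methoxy or an amine there would compare, and whether the number keeps falling along such a series or turns back. Also open, as far as these compounds go, is whether the same exchange of methyl and chloro would move the number in the same direction on the ring pattern of compound 1, where the chloro sits in a different place.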